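Bromo in place of the ester on the shared core

The compounds below may be only part of what the source reports. "The series", "measured", "known", "first", "only" and "open" are said of these compounds alone.

Compounds measured so far:
compound 1 `CC(C)c1ccc(N2C(=O)C=CC2OCC(F)(F)F)cc1`: 5800 nM
compound 2 `Cc1ccc(N2C(=O)C=CC2OCC(F)(F)F)cc1`: 9380 nM
compound 3 `COC(=O)c1ccc(N2C(=O)C=CC2OCC(F)(F)F)cc1`: 5700 nM

All three compounds were tested in a functional assay on HeLa cells (Homo sapiens) for inhibition; a lower number here means a stronger inhibitor, a higher number a weaker inhibitor. They share one core and differ only in the group on the aromatic carbon of the outer ring. In this assay compound 3 gives 5700 nM, a number that sits alongside those of compound 1 and compound 2: the steps of a 1.0-fold lower number from compound 1 to compound 3 (0.01 log units; within the scatter) and a 1.6-fold lower number from compound 2 to compound 3 (0.22 log units; within the scatter) both lie within the scatter, as does the step of a 1.6-fold higher number from compound 1 to compound 2 (0.21 log units; within the scatter). So far, then, exchanging the group at this position has not moved the number beyond the noise of the measurement.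

Compound 4 `O=C1C=CC(OCC(F)(F)F)N1c1ccc(Br)cc1` takes the same position once more: bromo in place of methoxycarbonyl on an aromatic carbon. Among the measured compounds shown here, none of the measured steps involves bromo, so there is no direct precedent; the three steps that do exist at this position all stayed within the scatter, and the same outcome is the natural expectation here. Compound 4 is therefore expected to give about 6000 nM in this assay, with a likely range from 2500 nM to 15000 nM. Against compound 3 this would amount to an expected step of a 1.1-fold higher number from compound 3 to compound 4 (0.02 log units; within the scatter), a change not expected to exceed the scatter.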

Compound 4, half-maximal inhibitory concentration: 7060 nM
Compound 4: middle estimate off by 1.2-fold (0.07 log units), on the low side; the range from low to high includes it.
By their numbers in this assay, from the lowest: compounds 3, 1, 4 and 2 (each within the scatter of the next).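

Bromo, with 1 heavy atom and 0 hydrogen-bond acceptors, replaces the methoxycarbonyl, with 4 heavy atoms and 2 hydrogen-bond acceptors, and in this assay this larger change in the counted atoms still stays within the scatter (a 1.2-fold higher number from compound 3 to compound 4 (0.09 log units; within the scatter)). Bromo also stays within the scatter when set against the two carbon groups, methyl (a 1.3-fold lower number from compound 2 to compound 4 (0.12 log units; within the scatter)) and isopropyl (a 1.2-fold higher number from compound 1 to compound 4 (0.09 log units; within the scatter)), so the position now holds four different groups, among them one with a halogen atom and one with hydrogen-bond acceptors, and no pair of these compounds differs beyond the scatter. No measurement at hand accounts for this flat picture.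

On these data alone, whether the number in this assay would stay in the same place with an amine, a carboxylic acid or a longer chain on this aromatic carbon remains open. The four compounds also leave open what a change anywhere else on the shared core would do, as they differ from one another in this single place only.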